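Swapping One Aromatic Group on the Shared Core

The source may hold more compounds than are shown below. What is called first, only, known or untested is meant among the compounds shown, and "the series" means these compounds.

In an ADME assay for permeability, using PAMPA, at pH 7.4 (on this read-out lower numbers stand for lower permeability and higher numbers for higher permeability), compound 1 (`Cc1cc(NC(=O)Nc2ccc(OC(F)(F)F)cc2)c2ccccc2n1`) gives 531 10^-6 cm/s and compound 2 (`Cc1cc(NC(=O)Nc2ncccc2C)c2ccccc2n1`) gives 369 10^-6 cm/s, so compound 2 stands within the usual scatter of compound 1. Compound 3 (`Cc1cc(NC(=O)Nc2ccc(N)cc2)c2ccccc2n1`) has not yet been measured. It has 4-aminophenyl in place of 3-methylpyridin-2-yl on an amide-type nitrogen. For the measured compounds named here, no measured pair shows the effect of such a swap, so only a small move toward lower numbers is expected in this assay, not beyond the scatter. The expected change is a 1.7-fold lower number from compound 2 to compound 3 (0.22 log units; within the scatter). For compound 3 the estimate is 220 10^-6 cm/s, with a range of 90 10^-6 cm/s to 450 10^-6 cm/s.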

Compound 3, apparent permeability: 530 10^-6 cm/s
The estimate for compound 3 lay 2.4-fold (0.38 log units) below the measured number; measured number outside the range, above it.
By their numbers in this assay, from the lowest: compounds 2, 3 and 1 (each within the scatter of the next).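

In this assay, putting 4-aminophenyl in place of 3-methylpyridin-2-yl on an amide-type nitrogen gives a 1.4-fold higher number from compound 2 to compound 3 (0.16 log units; within the scatter) and so leaves the read-out within the scatter. Amino in place of trifluoromethoxy on an aromatic carbon gives a 1.0-fold lower number from compound 1 to compound 3 (0.00 log units; within the scatter) and thus also separates nothing on this read-out. Nothing measured here explains either step. The compounds shown leave open whether a phenyl group carrying a carboxylic acid, or a longer chain in place of the aromatic group, would move the number beyond the scatter.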